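The source may hold more compounds than are shown below. What is called first, only, known or untested is meant among the compounds shown, and "the series" means these compounds.

Measured in a functional assay on the whole organism with Mus musculus as the target; a lower number here means that less compound is needed, a higher number that more compound is needed for the effect:
Compound 1 `NC(=O)/C=C1\CCc2c(F)cccc21`: > 100 mg/kg, a limit of the assay and not a number.
Compound 2 `NC(=O)/C=C1\CCc2ccc(Br)cc21`: 96 mg/kg.
Compound 3 `NC(=O)/C=C1\CCc2ccc(Cl)cc21`: 98 mg/kg.

Within the data shown here, compound 3 stands at 98 mg/kg, and compound 2, the only other compound with a number, gives 96 mg/kg. These two values lie within the scatter of each other. Compound 1 is known only through (the limit of > 100 mg/kg in this assay, at which 1 of the 3 values shown sits).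

The next compound is compound 4 `NC(=O)/C=C1\CCc2ccccc21`, which differs from compound 3 by hydrogen in place of chloro on an aromatic carbon. Among the measured compounds shown here, one measured step bears on this change, and only indirectly. It is a 1.0-fold higher number from compound 2 to compound 3 (0.01 log units; within the scatter), with chloro in place of bromo on an aromatic carbon, and it stays within the scatter. For the measured compounds named here, that step exchanges one halogen for another, and no measured step shows what hydrogen does at this carbon.

With that single step as the guide, no change beyond the scatter is expected in this assay, although a result reported only as a limit, as for compound 1, remains possible. The estimated step is a 1.1-fold higher number from compound 3 to compound 4 (0.05 log units; within the scatter). Compound 4 is therefore estimated at 110 mg/kg, with an expected range of 55 mg/kg to 220 mg/kg.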

Compound 4, dose for half-maximal effect: 108 mg/kg
The estimate for compound 4 lay 1.0-fold (0.01 log units) above the measured number; the range from low to high includes it.
By their numbers in this assay, from the lowest: compounds 2, 3 and 4 (each within the scatter of the next).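

In this assay, among these compounds, the earlier compounds showed only one halogen exchanged for another on the aromatic ring; now hydrogen in place of chloro gives a 1.1-fold higher number from compound 3 to compound 4 (0.04 log units; within the scatter), and hydrogen in place of bromo gives a 1.1-fold higher number from compound 2 to compound 4 (0.05 log units; within the scatter). Among these three compounds, then, whether this aromatic carbon carries chloro, bromo or just hydrogen makes no difference beyond the scatter, so neither halogen is needed for the dose seen here. Compound 1, which carries fluoro, gives > 100 mg/kg, a limit of the assay and not a number, and the step from it to compound 4 cannot be read: the limit of > 100 mg/kg in this assay, at which 1 of the 4 values shown sits.

The compounds shown leave open whether a group of another kind on this carbon, such as a methoxy group, an amine or a carboxylic acid, would move the number beyond the scatter in either direction. They also leave open whether a change away from this ring, for example replacing the amide hydrogen with a methyl group or a longer chain, would do so.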